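Hydroxy to methoxy on the tert-butyl amide

The compounds below may be only part of what the source reports. "The series", "measured", "known", "first", "only" and "open" are said of these compounds alone.

Measured in a functional assay on BT-474 cells (Homo sapiens) for antiproliferative activity, read by sulforhodamine B assay, with a stated time of 4 days; a higher number here means a weaker inhibitor of growth, a lower number a stronger inhibitor of growth
- compound 1 `COc1cc(Cl)c(-c2nc(SCC(=O)NC3CC3)nc3[nH]cc(C#N)c23)cc1OC` gives 69 nM
- compound 2 `COc1cc(Cl)c(-c2nc(SCC(=O)NC3CC3)nc3[nH]cc(C#N)c23)cc1O` gives 102 nM
- compound 3 `COc1cc(Cl)c(-c2nc(SCC(=O)NC(C)(C)C)nc3[nH]cc(C#N)c23)cc1O` gives 128 nM

Compound 3 stands at 128 nM and lies within the scatter of both compound 2 and compound 1, so this read-out does not separate the three. The next compound, compound 4 `COc1cc(Cl)c(-c2nc(SCC(=O)NC(C)(C)C)nc3[nH]cc(C#N)c23)cc1OC`, differs from compound 3 by methyl in place of hydrogen on an oxygen on an aromatic ring with methyl in place of hydrogen on an oxygen on an aromatic ring, that is, hydroxy to methoxy.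

Going by the values given here, one measured step bears directly on this change. Between compound 1 and compound 2 the same exchange runs in the opposite sense, with a 1.5-fold higher number from compound 1 to compound 2 (0.17 log units; within the scatter) as methyl gives way to hydrogen. The other step, a 1.3-fold higher number from compound 2 to compound 3 (0.10 log units; within the scatter), covers tert-butyl in place of cyclopropyl on an amide-type nitrogen. Among the compounds with values here, whether the oxygen exchange carries over from the cyclopropyl amide to the tert-butyl amide is untested, since only one such pair has been measured.

In this assay the expected result is a 1.4-fold lower number from compound 3 to compound 4 (0.15 log units; within the scatter) and so nothing beyond the scatter, with only a lean towards a lower number. Compound 4 is estimated at 90 nM with an expected range from 50 nM to 160 nM in this read-out.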

Compound 4, concentration for 50% growth inhibition: 121 nM
Beside the measured number, compound 4's estimate is 1.3-fold (0.13 log units) below it; the range from low to high includes it.
By their numbers in this assay, from the lowest: compounds 1, 2, 4 and 3 (each within the scatter of the next).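

In this assay, hydroxy to methoxy on the tert-butyl amide gives a 1.1-fold lower number from compound 3 to compound 4 (0.02 log units; within the scatter), so this oxygen has now been read on both amides, and neither pair leaves the scatter: the same change on two cores in this assay, a 1.5-fold higher number (0.17 log units; within the scatter) from compound 1 to compound 2 and a 1.1-fold higher number (0.02 log units; within the scatter) from compound 4 to compound 3, 1.4-fold (0.15 log units) apart, within the scatter of two such steps

The amide change now also has a second pair, on the methoxy compounds, where tert-butyl in place of cyclopropyl on an amide-type nitrogen gives a 1.8-fold higher number from compound 1 to compound 4 (0.24 log units; within the scatter); again both pairs stay within the scatter: the same change on two cores in this assay, a 1.3-fold higher number (0.10 log units; within the scatter) from compound 2 to compound 3 and a 1.8-fold higher number (0.24 log units; within the scatter) from compound 1 to compound 4, 1.4-fold (0.15 log units) apart, within the scatter of two such steps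

The four compounds thus close a square in which each of the two changes has been read twice, and no dependence of one change on the other can be seen in this read-out.

Going by these compounds, it remains open whether a group on this oxygen other than hydrogen or methyl, such as a longer chain ending in an amine, would move the number in this assay beyond the scatter. The same question stands for the amide-type nitrogen, where a chain ending in a carboxylic acid would test more than the cyclopropyl and tert-butyl groups shown here.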